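A few compounds are considered here, and "the series" means these few. Any claim that something is new, unique, unknown or untested is made for them only; others in the source may bear on it.

Series notes. In a functional assay on MCF7 cells (Homo sapiens), tested at 7.5 uM (on this read-out lower numbers stand for a stronger effect and higher numbers for a weaker effect at the one concentration tested), compound 1 `CC(C)=CCOc1c(C)c(C)c2c(c1C)CCC(C)(COc1ccc(/C=C3\SC(=O)NC3=O)cc1C)O2` gives 27%. Among the compounds with values here, compound 2 `CCOc1cc(/C=C2\SC(=O)NC2=O)ccc1OCC1(C)CCc2c(C)c(OCC=C(C)C)c(C)c(C)c2O1` gives 54% in this assay, the highest of the two numbers so far, its nearest neighbour being compound 1. Within the data shown here, the only measured step, a number 27 percentage points higher from compound 1 to compound 2 (beyond the scatter), is the one that bears on the next compound, and only indirectly. Compound 3 `CC(C)=CCOc1c(C)c(C)c2c(c1C)CCC(C)(COc1ccc(/C=C3\SC(=O)NC3=O)cc1Br)O2` differs from compound 2 thus: bromo in place of ethoxy on an aromatic carbon. Among the measured compounds shown here, no measured step places bromo at this carbon, so the expectation is loose. A downward step in this assay of roughly a number 19 percentage points lower from compound 2 to compound 3 (beyond the scatter) is expected. For compound 3 the estimate is 35%, within 15% to 60%.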

Compound 3, a percentage reported as activity, at one concentration (the size of the read-out at that concentration, not a potency): 53%
Compound 3: the middle estimate sits 18 percentage points below what was measured; the range from low to high includes it.
By their numbers in this assay, from the lowest: compound 1; then compounds 3 and 2 (each within the scatter of the next).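

Bromo in place of ethoxy at this aromatic carbon, ortho to a large group, gives a number 1 percentage points lower from compound 2 to compound 3 (within the scatter) in this assay so the two groups cannot be told apart on this read-out. Bromo in place of methyl gives a number 26 percentage points higher from compound 1 to compound 3 (beyond the scatter) and so a second replacement of methyl, with one heavy atom where ethoxy has three, also stands beyond the scatter from compound 1. No measurement at hand bears on the reason for this result.

Still open, going by these compounds, is whether methyl is unusual at this carbon or whether other groups would read like compound 1. An amine, a carboxylic acid or a longer chain such as propoxy at this carbon would test that.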